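Cyclohexyl in place of furan-3-yl on the shared core

The source may report more compounds than this note shows. Statements on the series, on what has been measured and on what is new or still open speak of the compounds shown alone.

In an ADME assay on Vero cells (Chlorocebus sabaeus) for cytotoxicity, read by MTT assay, with a stated time of 96 h (a higher number here means that more compound is tolerated, a lower number that less compound is tolerated), compound 1 (`COc1ccc(-c2nc3cc(/C(C)=N/NC(N)=S)ccc3[nH]2)cc1`) gives > 100000 nM as a limit of the assay and not a number. Among the measured compounds shown here, compound 2 (`C/C(=N\NC(N)=S)c1ccc2[nH]c(-c3ccoc3)nc2c1`) gives 100000 nM as the only true number so far. For the measured compounds named here, the one measured step is a number no higher from compound 1 to compound 2 (the limit leaves the size open) and its size stays open because of the limit of > 100000 nM in this assay, at which 1 of the 2 values shown sits, so it offers no scale. Compound 3 (`C/C(=N\NC(N)=S)c1ccc2[nH]c(C3CCCCC3)nc2c1`) follows through cyclohexyl in place of furan-3-yl on an aromatic carbon with cyclohexyl in place of furan-3-yl on an aromatic carbon. Nothing measured sizes this change, so the estimate stays close to compound 2 at 100000 nM in this assay with room downward. The expected step of a 1.3-fold lower number from compound 2 to compound 3 (0.10 log units; within the scatter) stays within the usual scatter. Compound 3 is expected at 80000 nM with 25000 nM to 100000 nM as its estimated range.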

Compound 3, half-maximal cytotoxic concentration: > 100000 nM
Compound 3: no number, only a limit (the forecaster's own chance of this, stated with the estimate: 35%); middle value at least 1.2-fold (0.09 log units) from the limit.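

In this assay, a non-aromatic ring of carbon only, cyclohexyl, on the aromatic carbon between two ring nitrogen atoms gives a number no lower from compound 2 to compound 3 (the limit leaves the size open). An aromatic ring at this place is therefore not required for a high tolerated concentration, which compound 1 and compound 2 alone could not show. No step among these compounds has a readable size, because of where the values sit: the limit of > 100000 nM in this assay, at which 2 of the 3 values shown sit.

On these data alone, whether any group at this place can lower the tolerated concentration stays open. An amine, a carboxylic acid or a longer chain there could test this.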